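Swapping a styryl arm for naphthyl in a sugar-linked oxindole

The source may hold more compounds than are shown below. What is called first, only, known or untested is meant among the compounds shown, and "the series" means these compounds.

Of the compounds shown here, two with a shared core have been measured in a functional assay on DU-145 cells (Homo sapiens) for cytotoxicity, read by sulforhodamine B assay, with a stated time of 48 h; on this read-out higher numbers stand for weaker inhibition and lower numbers for stronger inhibition. Compound 1 `CC(=O)OC[C@H]1O[C@@H](n2cc(CN3C(=O)/C(=C\c4ccccc4)c4ccccc43)nn2)[C@H](OC(C)=O)[C@@H](OC(C)=O)[C@@H]1OC(C)=O` carries a phenyl group and in this assay gives 24100 nM. Compound 2 `CC(=O)OC[C@H]1O[C@@H](n2cc(CN3C(=O)/C(=C\C=C\c4ccccc4)c4ccccc43)nn2)[C@H](OC(C)=O)[C@@H](OC(C)=O)[C@@H]1OC(C)=O` carries a 2-phenylethenyl group instead, and in this assay compound 2 gives 19500 nM. For the measured compounds named here, the only step so far, a 1.2-fold lower number from compound 1 to compound 2 (0.09 log units; within the scatter), tells that enlarging the group at this place did not move the read-out beyond the scatter, so compound 2 and compound 1 sit within the scatter of each other.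

Compound 3 `CC(=O)OC[C@H]1O[C@@H](n2cc(CN3C(=O)/C(=C\c4ccc5ccccc5c4)c4ccccc43)nn2)[C@H](OC(C)=O)[C@@H](OC(C)=O)[C@@H]1OC(C)=O` continues along the same place with a further change: naphthalen-2-yl in place of 2-phenylethenyl on a double-bonded chain carbon bound to a double-bonded ring carbon. Both enlarge an aromatic group at the same position. Going by the values given here, because the only comparable step, a 1.2-fold lower number from compound 1 to compound 2 (0.09 log units; within the scatter), stayed within the scatter, no movement beyond the scatter is expected in this assay, and the expected step is a 1.0-fold higher number from compound 2 to compound 3 (0.01 log units; within the scatter). Compound 3 is therefore estimated at 20000 nM, with a range from 8000 nM to 50000 nM.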

Compound 3, half-maximal inhibitory concentration: > 100000 nM
Compound 3: no number, only a limit (the forecaster's own chance of this, stated with the estimate: 10%); middle value at least 5.0-fold (0.69 log units) away from the limit.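

In this assay, this place on the double-bonded chain carbon turns out not to accept every aromatic group alike: naphthalen-2-yl gives an at least 5.1-fold higher number from compound 2 to compound 3 (0.70 log units; beyond the scatter) and an at least 4.1-fold higher number from compound 1 to compound 3 (0.61 log units; beyond the scatter). For the compounds shown here, the earlier change from phenyl to 2-phenylethenyl stayed within the scatter, so adding carbon atoms here does not by itself predict the outcome, and the change to the two six-membered aromatic rings of naphthalen-2-yl is the first to move the read-out beyond it. The true size of both steps remains unknown, as compound 3 has only a limit of the assay and not a number: the limit of > 100000 nM in this assay, at which 1 of the 3 values shown sits.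

On these data alone, it remains open whether naphthalen-1-yl would behave like naphthalen-2-yl. As far as these compounds go, it is also open whether a phenyl ring carrying an amine or a carboxylic acid would stay close to compound 1 at this place.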